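The source may hold more compounds than are shown below. What is called first, only, known or untested is meant among the compounds shown, and "the series" means these compounds.

For the measured compounds named here, compound 2 `Fc1cc(Cl)ccc1-c1ccc(Cn2nnc3c(C(F)(F)F)cccc32)cn1` stands lowest of the two numbers so far in an ADME assay on microsomes from liver (Rattus norvegicus, strain Wistar) for metabolic stability, tested at 2.5 uM (on this read-out higher numbers stand for fast clearance and lower numbers for slow clearance), giving 0.2 mL/min/g; its nearest neighbour is compound 1 `Fc1cc(Cl)ccc1-c1ccc(Cn2nnc3c(F)cccc32)cn1`, which in this assay gives 0.6 mL/min/g. Going by the values given here, the single measured step, a 3.0-fold lower number from compound 1 to compound 2 (0.48 log units; beyond the scatter), is the only change recorded at the same aromatic carbon. Compound 3 `Fc1cc(Cl)ccc1-c1ccc(Cn2nnc3c(Br)cccc32)cn1` has not yet been measured; it differs from compound 2 by bromo in place of trifluoromethyl on an aromatic carbon. Among the compounds with values here, no measured pair sets bromo against trifluoromethyl, so the expectation in this assay rests on that one step alone, taken as a guide to how much a group at this aromatic carbon has moved the number. The expected step is a 1.8-fold higher number from compound 2 to compound 3 (0.24 log units; within the scatter), a small rise that may not clear the scatter. The estimate for compound 3 in this assay is 0.35 mL/min/g, with a range from 0.15 mL/min/g to 0.8 mL/min/g. The measured number for compound 3 is awaited.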

Compound 3, intrinsic clearance in a liver preparation (reported as CLH), per the amount of preparation that the assay uses: 0.4 mL/min/g
Beside the measured number, compound 3's estimate is 1.1-fold (0.06 log units) below it, within the range that was stated.
By their numbers in this assay, from the lowest: compounds 2, 3 and 1 (each within the scatter of the next, the first and the last beyond it).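

In this assay, bromo at this aromatic carbon cannot be separated from either of the other two groups: a 2.0-fold higher number from compound 2 to compound 3 (0.30 log units; within the scatter) and a 1.5-fold lower number from compound 1 to compound 3 (0.18 log units; within the scatter) both lie within the scatter. For the compounds shown here, the trifluoromethyl-for-fluoro pair therefore remains the only one of the three pairs at this carbon that is beyond the scatter, and bromo, with a single heavy atom in place of four, does not resolve to either end. Nothing measured here bears on why these numbers fall as they do.

On these data alone, whether a different kind of group at this aromatic carbon, such as an amine, a methoxy or a carboxylic acid, would move the number outside the span of fluoro, bromo and trifluoromethyl stays open. As far as these compounds go, these steps are also read on the shared core alone, so whether they carry over to a core changed elsewhere is unknown.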